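Sulfonyl aryl swap in the quinoline sulfone series

The compounds below may be only part of what the source reports. "The series", "measured", "known", "first", "only" and "open" are said of these compounds alone.

Compound 3 `COc1ccc(S(=O)(=O)c2cnc3ccc(OC)cc3c2N2CCC(C)CC2)cc1` gives 41% in an assay on isolated protein for displacement of a labelled ligand from metabotropic glutamate receptor 5 (Homo sapiens), with a stated time of 60 min, tested at 1 uM (a higher number here means more inhibition at the concentration tested (going by the name of the read-out), a lower number less inhibition), the second highest of the three numbers. Compound 1 `COc1ccc(S(=O)(=O)c2cnc3ccc(F)cc3c2N2CCC(C)CC2)cc1` gives 85% in this assay; the step of a number 44 percentage points lower from compound 1 to compound 3 (beyond the scatter) is the change methoxy in place of fluoro on an aromatic carbon. Compound 2 `COc1ccc2ncc(S(=O)(=O)c3cc(F)cc(F)c3)c(N3CCC(C)CC3)c2c1` gives 30% in this assay; the step of a number 11 percentage points higher from compound 2 to compound 3 (beyond the scatter) is 4-methoxyphenyl in place of 3,5-difluorophenyl on a sulfonyl sulfur.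

Compound 4 `COc1ccc2ncc(S(=O)(=O)c3cccc(Cl)c3)c(N3CCC(C)CC3)c2c1` has not been measured. It differs from compound 3 by 3-chlorophenyl in place of 4-methoxyphenyl on a sulfonyl sulfur. For the measured compounds named here, only the step from compound 2 to compound 3 touches the same position, and it was modest; the step from compound 1 to compound 3 lies on a different carbon and does not bear on this change. A return from the 4-methoxyphenyl to a halogenated phenyl is therefore expected to lower the number modestly or leave it within the scatter. Compound 4 is expected to give 35% in this assay, between 15% and 55%, an estimated step of a number 6 percentage points lower from compound 3 to compound 4 (within the scatter).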

Compound 4, a percentage reported as inhibition, at one concentration (the size of the read-out at that concentration, not a potency): -3%
Estimate against measurement, compound 4: 38 percentage points above, outside the stated range (below it).
By their numbers in this assay, from the lowest: compound 4; then compound 2; then compound 3; then compound 1.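

The sulfonyl aryl group proves far more sensitive than the earlier modest step suggested: in this assay there is a number 44 percentage points lower from compound 3 to compound 4 (beyond the scatter), as large as the fluoro-to-methoxy change on the core. Halogenated phenyls also do not behave as one group, since exchanging one for another gives a number 33 percentage points lower from compound 2 to compound 4 (beyond the scatter), so the presence of halogen on this ring does not by itself set the read-out. No measurement available here accounts for either step.

Open, as far as these compounds go, is whether the loss on moving to 3-chlorophenyl carries over to the core of compound 1, where the 4-methoxyphenyl compound gives the top number of the set. Also open, from the compounds shown here alone, is how an unsubstituted phenyl or a pyridyl ring on the sulfonyl sulfur would compare with these aryl groups.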